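The source may report more compounds than this note shows. Statements on the series, on what has been measured and on what is new or still open speak of the compounds shown alone.

Compound 1 `CCNC(=O)c1noc(-c2cc(C(C)C)c(O)cc2O)c1-c1cc(COCC(N)=O)no1`: 97 nM
Compound 2 `CCNC(=O)c1noc(-c2cc(C(C)C)c(O)cc2O)c1-c1cc(CNC(C)=O)no1`: 167 nM

In a functional assay on HCT-116 cells (Homo sapiens) for inhibition (on this read-out higher numbers stand for weaker inhibition and lower numbers for stronger inhibition), compound 2 has the highest of the two numbers, and the nearest is compound 1; the step of a 1.7-fold higher number from compound 1 to compound 2 (0.24 log units; within the scatter) lies within the scatter. Compound 3 `CCNC(=O)c1noc(-c2cc(C(C)C)c(O)cc2O)c1-c1cnn(C(C)C)c1` differs from compound 2 in one place: 1-isopropyl-1H-pyrazol-4-yl in place of 3-(acetamidomethyl)-1,2-oxazol-5-yl on an aromatic carbon. Going by the values given here, the only measured step, a 1.7-fold higher number from compound 1 to compound 2 (0.24 log units; within the scatter), changed a group on a saturated chain carbon and left the five-membered ring in place, so it does not bear on this exchange of one ring for another. Among the compounds with values here, with no comparable step, no change beyond the scatter in this assay is expected. Compound 3 is expected to give 170 nM, between 45 nM and 650 nM, a step of a 1.0-fold higher number from compound 2 to compound 3 (0.01 log units; within the scatter).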

Compound 3, half-maximal inhibitory concentration: 21 nM
Estimate against measurement, compound 3: 8.1-fold (0.91 log units) above; the measured number lies below the stated range.
By their numbers in this assay, from the lowest: compound 3; then compounds 1 and 2 (each within the scatter of the next).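

This aromatic carbon responds to a whole-group exchange, which the earlier chain change could not show: in this assay 1-isopropyl-1H-pyrazol-4-yl in place of 3-(acetamidomethyl)-1,2-oxazol-5-yl gives an 8.0-fold lower number from compound 2 to compound 3 (0.90 log units; beyond the scatter) and this step lies beyond the scatter. The exchange alters the ring and the chain on it together, so these compounds cannot assign the gain to either part. No measurement at hand explains the gain. As far as these compounds go, it stays open whether the isopropyl group is needed, and how a longer chain or an amine on the pyrazole ring nitrogen would compare.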